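The source may report more compounds than this note shows. Statements on the series, on what has been measured and on what is new or still open speak of the compounds shown alone.

Compound 1 `COc1cccc(CNCCCNc2ccnc3cc(Cc4ccccc4)ccc23)c1O` is measured in a physicochemical assay for solubility, with a stated time of 18 h, at pH 7.4 (a lower number here means a less soluble compound, a higher number a more soluble compound), where compound 1 gives 4200 nM. Compound 3 `COc1ccc(F)cc1CNCCCNc1ccnc2cc(Cc3ccccc3)ccc12` gives 4200 nM, and compound 2 `COc1ccc(Oc2ccc3c(NCCCNCc4ccco4)ccnc3c2)cc1` gives 14500 nM. Compound 1 thus stands level with compound 3 at the digits shown, the two lowest of the three numbers, with compound 2 the furthest away at a higher number. For the measured compounds named here, the one step between two compounds that differ in a single place runs no change at the digits printed from compound 1 to compound 3 (within the scatter), a change that sits on the other end of the molecule from the change now in question.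

Compound 4 `COc1cccc(CNCCCNc2ccnc3cc(CC4CCCCC4)ccc23)c1O` differs from compound 1 in one place: cyclohexyl in place of phenyl on a saturated chain carbon bound to an aromatic carbon. Going by the values given here, no measured step touches this position, so the step from compound 1 to compound 3 offers only the general impression that a change at one end left the number unmoved. Taking that as a weak guide, compound 4 is expected to show a step of a 1.4-fold lower number from compound 1 to compound 4 (0.15 log units; within the scatter) and a value of about 3000 nM, estimated to fall between 1200 nM and 9000 nM.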

Compound 4, solubility: 4200 nM
Compound 4: middle estimate off by 1.4-fold (0.15 log units), on the low side; the measured number falls inside the stated range.
By their numbers in this assay, from the lowest: compounds 1, 3 and 4 (each within the scatter of the next); then compound 2.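

In this assay, the step at this position, no change at the digits printed from compound 1 to compound 4 (within the scatter), comes from putting cyclohexyl in place of phenyl on a saturated chain carbon bound to an aromatic carbon. For the compounds shown here, the earlier step changed a different place, so this is the first sign that, in this pair, a non-aromatic six-membered carbon ring can stand in for the aromatic one with the same count of heavy atoms and leave the number within the scatter. Nothing measured here explains that result.

As far as these compounds go, whether the position stays as unresponsive with an amine or a carboxylic acid in place of phenyl remains open. So does whether cyclohexyl would give the same result on the 5-fluoro-2-methoxyphenyl form seen in compound 3.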